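Changing the Ring on Compound 2

The compounds below may be only part of what the source reports. "The series", "measured", "known", "first", "only" and "open" are said of these compounds alone.

In an ADME assay on microsomes from liver (Mus musculus) for metabolic stability, read by LC-MS, with a stated time of 10 min (a higher number here means that more of the compound is left, a lower number that less of the compound is left), compound 2 (`CN(C[C@H]1Cc2c(cccc2N2CCNC(C)(C)C2)CN1)[C@H]1CCCc2cccnc21`) gives 44%, the lowest of three numbers. Compound 1 (`CN(C[C@@H]1Cc2c(cccc2N2CCNCC2)CN1)[C@H]1CCCc2cccnc21`) gives 54.6% and compound 3 (`FC1(F)CCC(CN(C[C@H]2Cc3c(cccc3N3CCNCC3)CN2)[C@H]2CCCc3cccnc32)CC1`) gives 76.6%, both higher than compound 2 by more than the scatter. Compound 4 (`CN(C[C@H]1Cc2c(cccc2N2C[C@H]3C[C@@H]2CN3)CN1)[C@H]1CCCc2cccnc21`) differs from compound 2 in the group on an aromatic carbon: a group of 7 heavy atoms (5 carbon, 2 nitrogen; 2 five-membered non-aromatic rings with 1 hetero atom each) in place of a group of 8 heavy atoms (6 carbon, 2 nitrogen; one six-membered non-aromatic ring with 2 hetero atoms), on an aromatic carbon. Going by the values given here, no two measured compounds differ in one place only, so no direct step guides this change. Compound 1, at 54.6%, also carries a smaller group on that carbon than compound 2 does. A small upward move is therefore expected, and the estimated a number 7 percentage points higher from compound 2 to compound 4 (within the scatter) would stay within the scatter. For compound 4 the expected value is 51%, with an estimated range from 36% to 66%.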

Compound 4, percent of the compound remaining: 95.9%
Compound 4: the middle estimate sits 44.9 percentage points below what was measured, outside the stated range (above it).
By their numbers in this assay, from the lowest: compound 2; then compound 1; then compound 3; then compound 4.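

In this assay, the change of group on this aromatic carbon gives a number 51.9 percentage points higher from compound 2 to compound 4 (beyond the scatter). With everything else in the molecule the same, this shows that the group at this position alone can strongly change how much compound is left, even though the two groups have the same hydrogen-bond donor and acceptor counts. Nothing measured here explains the size of this step. As far as these compounds go, whether a morpholine ring at this carbon would behave like either group stays open, and so does whether the same change would give a similar step with the difluorocyclohexylmethyl group of compound 3 in place.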